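A few compounds are considered here, and "the series" means these few. Any claim that something is new, unique, unknown or untested is made for them only; others in the source may bear on it.

- compound 1 `O=C1CCc2cc(NC(=O)C[C@]3(O)CC[C@@H](Cc4ccccc4)CC3)ccc2N1` gives 24.4 mL/min/kg as its clearance
- compound 2 `O=c1[nH]c2ccc(-c3cc(C[C@]4(O)CC[C@@H](Cc5ccccc5)CC4)no3)cc2o1` gives 12.1 mL/min/kg as its clearance
- compound 3 `O=c1[nH]c2ccc(-c3cc(C[C@]4(O)CC[C@@H](Cc5ccc(Cl)cc5)CC4)no3)cc2o1` has no number for its clearance: "not determined" (no result reported)

For the measured compounds named here, in an ADME assay on the whole organism (strain Sprague-Dawley) for pharmacokinetics, with Rattus norvegicus as the target, using cassette dosing (a higher number here means faster removal of the compound, a lower number slower removal), only two numbers exist, and compound 2 at 12.1 mL/min/kg lies within the usual scatter of compound 1 at 24.4 mL/min/kg on this read-out. Compound 4 `O=c1ccc(-c2cc(C[C@]3(O)CC[C@@H](Cc4ccccc4)CC3)no2)c[nH]1` remains unmeasured. Its structure differs from that of compound 2 as follows: a group of 7 heavy atoms (5 carbon, 1 nitrogen, 1 oxygen; one six-membered aromatic ring with 1 hetero atom) in place of a group of 10 heavy atoms (7 carbon, 1 nitrogen, 2 oxygen; one five-membered aromatic ring with 2 hetero atoms, one six-membered aromatic ring of carbon only), on an aromatic carbon. The change sits on an aromatic carbon of a five-membered aromatic ring with 1 nitrogen and 1 oxygen. Going by the values given here, no measured pair shows this change, so the data give no direction, and a step no larger than the scatter is expected. The expected 1.2-fold higher number from compound 2 to compound 4 (0.09 log units; within the scatter) is only a working figure. For compound 4 the estimate is 15 mL/min/kg, with an expected range of 7 mL/min/kg to 32 mL/min/kg in this assay.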

Compound 4, clearance: 37.6 mL/min/kg
Estimate against measurement, compound 4: 2.5-fold (0.40 log units) below, outside the stated range (above it).
By their numbers in this assay, from the lowest: compounds 2, 1 and 4 (each within the scatter of the next, the first and the last beyond it).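

In this assay, a 3.1-fold higher number from compound 2 to compound 4 (0.49 log units; beyond the scatter) accompanies the replacement of the group of 10 heavy atoms by the group of 7 heavy atoms on an aromatic carbon next to the ring oxygen. For the compounds shown here, this is the only readable step, and it shows that clearance responds to the group at this place, with faster removal for the single six-membered aromatic ring with 1 hetero atom. No available evidence bears on the reason for this step.

Going by these compounds, how a plain phenyl, an amine or a carboxylic acid at this place would compare remains open. On these data alone, whether the step carries over to other substituents on the benzyl group also remains open.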